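Swapping a fluorinated ester arm for an oxetane ring

The source may report more compounds than this note shows. Statements on the series, on what has been measured and on what is new or still open speak of the compounds shown alone.

Compound 1 `Cc1nc(S(C)(=O)=O)ccc1Oc1ncnc(OC2CCN(C(=O)OC(C)(C)CF)CC2)c1F` gives 138 nM in a functional assay on isolated protein for inhibition of Glucose-dependent insulinotropic receptor (Rattus norvegicus), read by HTRF and cAMP accumulation; on this read-out higher numbers stand for an effect only at larger amounts of compound and lower numbers for an effect already at smaller amounts.
Compound 2 `Cc1nc(S(C)(=O)=O)ccc1Oc1ncnc(OC2CCN(C(=O)O[C@H](C)CF)CC2)c1F` gives 1520 nM in this assay.
Compound 3 `Cc1nc(S(C)(=O)=O)ccc1Oc1ncnc(OC2CCN(C(=O)O[C@H](C)C(F)(F)F)CC2)c1F` gives 110 nM in this assay.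

Compound 3 shows the lowest number of the three, but its gap to compound 1 is within the scatter, so the two cannot be ranked; only compound 2 stands clearly apart. The three compounds share one core and differ only in the group on the oxygen next to a carbonyl group. Compound 4 `Cc1nc(S(C)(=O)=O)ccc1Oc1ncnc(OC2CCN(C(=O)OC3COC3)CC2)c1F` continues this series: oxetan-3-yl in place of 1-(trifluoromethyl)ethyl on an oxygen next to a carbonyl group.

Two measured steps speak to how sensitive this position is. The change an 11-fold higher number from compound 1 to compound 2 (1.04 log units; beyond the scatter) and the change a 14-fold lower number from compound 2 to compound 3 (1.14 log units; beyond the scatter) both show that taking fluorine out of this small side group, or making it less bulky, can move the number a great deal, while a 1.3-fold lower number from compound 1 to compound 3 (0.10 log units; within the scatter) shows that two fluorine-rich groups sit close together. The oxetan-3-yl group carries no fluorine at all and is smaller than the groups it replaces, so compound 4 is expected to land nearer compound 2 than compound 3, with a step of a 6.4-fold higher number from compound 3 to compound 4 (0.80 log units; beyond the scatter). The estimate for compound 4 is 700 nM, within a range of 200 nM to 3000 nM.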

Compound 4, half-maximal effective concentration: 2500 nM
Estimate against measurement, compound 4: 3.6-fold (0.55 log units) below; the range from low to high includes it.
By their numbers in this assay, from the lowest: compounds 3 and 1 (each within the scatter of the next); then compounds 2 and 4 (each within the scatter of the next).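

In this assay, replacing either of the two fluorinated groups at the low end of the series with oxetan-3-yl costs a great deal (from the first, a 23-fold higher number from compound 3 to compound 4 (1.36 log units; beyond the scatter); from the second, an 18-fold higher number from compound 1 to compound 4 (1.26 log units; beyond the scatter)). The step to the remaining open-chain group tells a different story (here, a 1.6-fold higher number from compound 2 to compound 4 (0.22 log units; within the scatter)), so a ring carrying an oxygen and no fluorine cannot be told apart from 1-(fluoromethyl)ethyl at this position, even though the two groups look quite different. The four compounds therefore fall into two clear pairs, one with 1-(trifluoromethyl)ethyl and 1-(fluoromethyl)-1-methylethyl and one with 1-(fluoromethyl)ethyl and oxetan-3-yl, and no measurement available here explains this split.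

On these data alone, what stays open is whether the ring, its oxygen or the loss of fluorine sets the value, since oxetan-3-yl differs from 1-(trifluoromethyl)ethyl in all of these at once. A cyclobutyl group, which keeps a four-membered ring but has only carbon in it, would begin to pull these apart, and an open-chain group such as isopropyl, with no fluorine and no ring, would test the loss of fluorine alone.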